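This account rests on a few compounds, and the source may have more. Where it says the series, first, only, none or still open, it means among the compounds named here.

Measured compounds in an assay on isolated protein for inhibition of protein kinase C theta type (Homo sapiens), read by TR-FRET, with a stated time of 2 h; on this read-out lower numbers stand for stronger inhibition and higher numbers for weaker inhibition:
compound 1, `CO[C@H]1CC[C@@H](Nc2cc(NCc3cnccc3C(F)(F)F)ncc2C#N)CC1`: 58 nM
compound 2, `CO[C@H]1CC[C@@H](CNc2cc(NCc3cnccc3C(F)(F)F)ncc2C#N)CC1`: 70 nM
compound 3, `CC1(C)C[C@H](Nc2cc(NCc3cnccc3C(F)(F)F)ncc2C#N)CC[C@@H]1O`: 7 nM

Compound 3 gives the lowest number of the three in this assay. Its nearest neighbour is compound 1, and the step of an 8.3-fold lower number from compound 1 to compound 3 (0.92 log units; beyond the scatter) is beyond the scatter; the step of a 10-fold lower number from compound 2 to compound 3 (1.00 log units; beyond the scatter) is slightly larger. Between compound 1 and compound 2 the step of a 1.2-fold higher number from compound 1 to compound 2 (0.08 log units; within the scatter) is within the scatter, so those two are not separated. Both steps into compound 3 exchange the whole substituent on the ring nitrogen, so neither speaks to a change in configuration alone.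

Compound 4, `CC1(C)C[C@H](Nc2cc(NCc3cnccc3C(F)(F)F)ncc2C#N)CC[C@H]1O`, differs from compound 3 as follows: the two compounds have the same atoms and bonds and differ only in configuration as drawn: 1 of 2 stereo elements differ; a stereocentre at a saturated ring carbon is drawn S in compound 3 and R in compound 4. For the measured compounds named here, no measured step in this set alters only the drawn configuration at a saturated ring carbon, so there is no direct precedent for the size or direction of the effect in this assay. On these data alone, the expectation therefore rests on compound 3 at 7 nM as the anchor, with a wide range in both directions and a lean toward a somewhat higher number, since the configuration change is untested here.

Compound 4 is expected to give 25 nM, within a range from 6 nM to 100 nM. This estimate corresponds to an expected step of a 3.6-fold higher number from compound 3 to compound 4 (0.55 log units; beyond the scatter).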

Compound 4, half-maximal inhibitory concentration: 100 nM
Compound 4: the middle estimate sits 4.0-fold (0.60 log units) below what was measured, and the stated range covers the measured number.
By their numbers in this assay, from the lowest: compound 3; then compounds 1, 2 and 4 (each within the scatter of the next).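

In this assay, for the compounds shown here, a 14-fold higher number from compound 3 to compound 4 (1.15 log units; beyond the scatter) is the first reading of a change in drawn configuration alone at a saturated ring carbon, and it is a large one. The whole step can be assigned to that stereocentre because of one fact: the fact that compounds 3 and 4 differ only in the configuration as drawn

The 4-hydroxy-3,3-dimethylcyclohexyl group therefore does not give a low number by itself: with this stereocentre drawn R, it is no longer separated from the two methoxy-bearing substituents, as a 1.7-fold higher number from compound 1 to compound 4 (0.24 log units; within the scatter) and a 1.4-fold higher number from compound 2 to compound 4 (0.15 log units; within the scatter) both lie within the scatter. The separation of compound 3 from compound 1 and compound 2 thus belongs to this group only with the stereocentre drawn as it is in compound 3.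

Still open, on these data alone, is what the two methyl groups contribute, a question that a plain 4-hydroxycyclohexyl group would address, and whether an amine or a fluorine in place of the hydroxy would keep the same preference between the two configurations. As far as these compounds go, the role of the second stereo element, which is common to compound 3 and compound 4, also remains open.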